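Lengthening the Chain from Aryl to Phenylpropyl

This account rests on a few compounds, and the source may have more. Where it says the series, first, only, none or still open, it means among the compounds named here.

Measured compounds:
Compound 1 `CC(CC(=O)O)CC(=O)c1c(CCCc2ccccc2)n(C)c2ccc(Cl)cc12` gives 223 nM in a functional assay for antagonist activity at Oxoeicosanoid receptor 1 (Homo sapiens), read by fluorescence and calcium flux, with stated times of 2 min and 1 min; on this read-out higher numbers stand for weaker inhibition and lower numbers for stronger inhibition.
Compound 2 `CC(CC(=O)O)CC(=O)c1c(CCCCCC(F)(F)F)n(C)c2ccc(Cl)cc12` gives 38 nM in this assay.
Compound 3 `CC(CC(=O)O)CC(=O)n1c(CCCc2ccccc2)cc2ccc(Cl)cc21` gives 210 nM in this assay.

Compound 3 stands with compound 1 among the larger numbers; the two lie within the scatter of each other, so nothing separates them. Compound 2 stands apart with a smaller number, beyond the scatter from compound 3.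

Compound 4 `CC(CC(=O)O)CC(=O)n1c(CCCCCCc2ccccc2)cc2ccc(Cl)cc21` is not yet measured. It differs from compound 3 in one place: 3-phenylpropyl in place of phenyl on a saturated chain carbon, three bonds along the chain from an aromatic carbon. The chain that carries the aromatic ring is thus extended, while the ring itself stays.

One measured step speaks to a change at this same place. Going a 5.9-fold lower number from compound 1 to compound 2 (0.77 log units; beyond the scatter), the phenyl gave way to a fluorinated chain, a different group altogether, so it is only a loose guide. Within the data shown here, no measured pair shows what extending the chain while keeping the phenyl does. Given that uncertainty, the step of a 1.6-fold lower number from compound 3 to compound 4 (0.21 log units; within the scatter) is expected to be small, and a change beyond the scatter is not expected with any confidence. Compound 4 is therefore estimated at 130 nM, with a plausible range from 40 nM to 450 nM.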

Compound 4, half-maximal inhibitory concentration: 12 nM
The estimate for compound 4 lay 11-fold (1.03 log units) above the measured number, outside the stated range (below it).
By their numbers in this assay, from the lowest: compound 4; then compound 2; then compounds 3 and 1 (each within the scatter of the next).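

Going an 18-fold lower number from compound 3 to compound 4 (1.24 log units; beyond the scatter) in this assay, the result shows that this position is highly sensitive to the length of the chain carrying the phenyl ring. Among these compounds, the only earlier step at this place, from compound 1 to compound 2, replaced the phenyl with a fluorinated chain, so it could not separate the effect of chain length from the effect of losing the ring; here the ring stays, and the large step goes with 3-phenylpropyl entering in place of phenyl. No measurement shown gives a reason for a step of this size.

The compounds shown leave open whether a still longer chain, such as one ending in a phenyl group with more carbons before it, would extend this trend or reverse it, and whether a cyclohexyl ring or an amine could take the place of the phenyl at the end of the longer chain. They also leave open whether the same lengthening on the core of compound 1 would give a step of similar size.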